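This account rests on a few compounds, and the source may have more. Where it says the series, first, only, none or still open, it means among the compounds named here.

Compound 2 `CC(=O)Nc1nnc(-c2cccc(O)c2O)s1` and compound 1 `O=C(Nc1nnc(-c2cccc(O)c2O)s1)c1ccccc1` share one core, and compound 3 `CC(=O)Nc1nnc(-c2ccc(O)c(O)c2)s1` is built on a second core made of the same atoms joined differently; how the two cores differ is not broken down here. In a functional assay on HeLa cells (Homo sapiens) for cytotoxicity, read by MTT assay, with a stated time of 72 h (a lower number here means a stronger inhibitor, a higher number a weaker inhibitor), compound 2 gives 177000 nM, and compound 1 gives 21800 nM. The change between them, (phenyl in place of methyl on a carbonyl carbon), brings an 8.1-fold lower number from compound 2 to compound 1 (0.91 log units; beyond the scatter). For the measured compounds named here, on the second core, compound 3 gives 125000 nM in this assay; that number and the one for compound 2 lie within the scatter of each other, while the gap between compound 3 and compound 1 lies beyond it.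

Compound 4 `O=C(Nc1nnc(-c2ccc(O)c(O)c2)s1)c1ccccc1` has not yet been measured. Going by the values given here, it differs from compound 3 by phenyl in place of methyl on a carbonyl carbon, the same change, at the same kind of place, as the one from compound 2 to compound 1. Among the compounds with values here, with only that single earlier step to rest on, the size of the step from compound 3 to compound 4 is estimated at a 6.9-fold lower number from compound 3 to compound 4 (0.84 log units; beyond the scatter), close to the earlier one, because compound 2 to compound 1 showed an 8.1-fold lower number from compound 2 to compound 1 (0.91 log units; beyond the scatter). From the compounds shown here alone, whether the second core carries the change in the same measure is unknown, so the range is kept wide. In this assay compound 4 is expected to give about 18000 nM, most likely between 6000 nM and 55000 nM.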

Compound 4, half-maximal inhibitory concentration: 23300 nM
Compound 4: middle estimate off by 1.3-fold (0.11 log units), on the low side, within the range that was stated.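

In this assay, phenyl in place of methyl on a carbonyl carbon also lowers the number on the second core, giving a 5.4-fold lower number from compound 3 to compound 4 (0.73 log units; beyond the scatter). Set beside the step on the first core, the size of the change cannot be told apart between the two cores, so in this series it carried over from one core to the other both in direction and, within the scatter, in size: the same change on two cores in this assay, an 8.1-fold lower number (0.91 log units; beyond the scatter) from compound 2 to compound 1 and a 5.4-fold lower number (0.73 log units; beyond the scatter) from compound 3 to compound 4, 1.5-fold (0.18 log units) apart, within the scatter of two such steps

For the compounds shown here, this agreement rests on only two pairs of compounds, a single change and a single cell-based read-out, so it shows neither that the step would hold on any further core nor why the two steps match, and it says nothing about how other changes at this place would carry over.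

The compounds shown leave open what happens on either core when the carbonyl carbon bears something other than methyl or phenyl, such as a longer chain, or a phenyl carrying an amine or a carboxylic acid. They also leave open whether the step would keep its size if methoxy groups stood in place of the hydroxyl groups that all four compounds share.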